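The source may report more compounds than this note shows. Statements on the series, on what has been measured and on what is new or still open speak of the compounds shown alone.

Measured compounds:
Compound 1, `CCCCCCCCn1cc(COC[C@@H]2OC[C@H](N)[C@H]2O)nn1`, in a functional assay on EC9706 cells (Homo sapiens) for antiproliferative activity, read by MTT assay, with a stated time of 48 h (a higher number here means a weaker inhibitor, a lower number a stronger inhibitor), compound 1 gives > 128000 nM; this is a limit of the assay, not a number.
Compound 2, `CCCCCCCCCCn1cc(COC[C@@H]2OC[C@H](N)[C@H]2O)nn1`, in this assay compound 2 gives 43100 nM.
Compound 3, `CCCCCCCCCCCCCCCCn1cc(COC[C@@H]2OC[C@H](N)[C@H]2O)nn1`, in this assay compound 3 gives 6310 nM.

Each lengthening of the chain lowers the number: an at least 2.9-fold lower number from compound 1 to compound 2 (0.47 log units; beyond the scatter), resting on (the limit of > 128000 nM in this assay, at which 1 of the 3 values shown sits); a 6.8-fold lower number from compound 2 to compound 3 (0.83 log units; beyond the scatter); and an at least 20-fold lower number from compound 1 to compound 3 (1.30 log units; beyond the scatter).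

Compound 4, `CCCCCCCCCCCCCCCCCCn1cc(COC[C@@H]2OC[C@H](N)[C@H]2O)nn1`, is not yet measured. It differs from compound 3 by ethyl in place of hydrogen on a saturated chain carbon, ten or more bonds along the chain from an aromatic nitrogen. The same kind of change is seen as ethyl in place of hydrogen on a saturated chain carbon, eight bonds along the chain from an aromatic nitrogen, which gave an at least 2.9-fold lower number from compound 1 to compound 2 (0.47 log units; beyond the scatter); the two changes differ only in where along the chain they sit, as the two differences themselves show. The two cores differ by octyl in place of hydrogen on a saturated chain carbon, eight bonds along the chain from an aromatic nitrogen.

The step expected here, a 1.8-fold lower number from compound 3 to compound 4 (0.26 log units; within the scatter), is smaller than the earlier one because a 6.8-fold lower number from compound 2 to compound 3 (0.83 log units; beyond the scatter), spread over more carbons, shows the gain per added carbon shrinking. Compound 4 is expected to give about 3500 nM, between 1200 nM and 12000 nM.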

Compound 4, half-maximal inhibitory concentration: 2290 nM
The estimate for compound 4 lay 1.5-fold (0.18 log units) above the measured number; the range from low to high includes it.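

In this assay, ethyl in place of hydrogen on the chain again lowers the number, a 2.8-fold lower number from compound 3 to compound 4 (0.44 log units; beyond the scatter), and set beside the earlier case the change points the same way on both cores: the same change on two cores in this assay, an at least 2.9-fold lower number (0.47 log units; beyond the scatter) from compound 1 to compound 2 and a 2.8-fold lower number (0.44 log units; beyond the scatter) from compound 3 to compound 4; the limit leaves it open whether they differ. Octyl in place of hydrogen gives a 19-fold lower number from compound 2 to compound 4 (1.27 log units; beyond the scatter), and it too compares with an earlier step: the same change on two cores in this assay, an at least 20-fold lower number (1.30 log units; beyond the scatter) from compound 1 to compound 3 and a 19-fold lower number (1.27 log units; beyond the scatter) from compound 2 to compound 4; the limit leaves it open whether they differ. The direction carries from core to core, but an equal size is not shown, and the widest step, an at least 55-fold lower number from compound 1 to compound 4 (1.74 log units; beyond the scatter), starts from a limit for compound 1, not a number.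

The compounds shown leave open whether a longer chain than that of compound 4 would lower the number further. They also leave open how a branched chain or a chain carrying a hydroxyl group would behave in this assay.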